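Compound 3 Faces a Limit Shared by Two Relatives

The source may report more compounds than this note shows. Statements on the series, on what has been measured and on what is new or still open speak of the compounds shown alone.

Of the compounds shown here, two have been read in an in vitro ADME assay on microsomes from Gut (Homo sapiens) for metabolic stability, using NADPH (on this read-out lower numbers stand for slow clearance and higher numbers for fast clearance), so far. Compound 1 (`CC(C)(CO)CNC(=O)c1cc2cc(C#N)ccc2n1Cc1cc(Cl)cc(Cl)c1`) gives < 6 mL.min-1.g-1 as a limit of the assay, not a number. Compound 2 (`CC(C)(O)CCNC(=O)c1cc2cc(C#N)ccc2n1Cc1cccc(OC(F)(F)F)c1`) gives < 6 mL.min-1.g-1 as a limit too, so it has no exact value. The whole record therefore amounts to one entry (the limit of < 6 mL.min-1.g-1 in this assay, at which 2 of the 2 values shown sit).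

Compound 3 (`N#Cc1ccc2c(c1)cc(C(=O)NCCC(O)(C(F)(F)F)C(F)(F)F)n2Cc1cccc(OC(F)(F)F)c1`) differs from compound 2 in one place (2,2,2-trifluoro-1-hydroxy-1-(trifluoromethyl)ethyl in place of 1-hydroxy-1-methylethyl on a saturated chain carbon, two bonds along the chain from an amide-type nitrogen). It carries 2,2,2-trifluoro-1-hydroxy-1-(trifluoromethyl)ethyl in place of 1-hydroxy-1-methylethyl on a saturated chain carbon, two bonds along the chain from an amide-type nitrogen.

Among the compounds with values here, no measured step shows what such a change does, so the expectation rests on the limit held by compound 2 (< 6 mL.min-1.g-1). In this assay the expected size of a number no lower from compound 2 to compound 3 (the limit leaves the size open) is none beyond the scatter, with no direction favoured. For compound 3 the estimated value is 6 mL.min-1.g-1 with an expected range from 3 mL.min-1.g-1 to 14 mL.min-1.g-1 and a good chance of only a limit again.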

Compound 3, intrinsic clearance in microsomes: < 6 mL.min-1.g-1
Compound 3 ended at the assay's limit; the forecaster's own chance of this, stated with the estimate: 70%; the middle value lies on the limit itself.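

In this assay compound 3 gives < 6 mL.min-1.g-1, a limit of the assay and not a number. Within the data shown here, compound 2 also stands at a limit, so no step between compound 2 and compound 3 can be read. The compounds shown leave open how fast each is actually cleared, and what the change of group does to that clearance: the limit of < 6 mL.min-1.g-1 in this assay, at which 3 of the 3 values shown sit.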